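This account rests on a few compounds, and the source may have more. Where it says the series, first, only, none or still open, it means among the compounds named here.

Values measured so far in a functional assay (strain AB) with Danio rerio as the target, read by microscopy, with a stated time of 1 h (on this read-out higher numbers stand for an effect only at larger amounts of compound and lower numbers for an effect already at smaller amounts), are:

- compound 1 `CC(C)(C)OC(=O)CCCC[N+]1(C)CCc2c(sc(NC(=O)Nc3ccc(Cl)cc3)c2C(N)=O)C1` gives 140 nM
- compound 2 `CN1CCc2c(sc(NC(=O)Nc3ccc(Cl)cc3)c2C(N)=O)C1` gives 4700 nM
- compound 3 `CC[N+]1(CC2CC2)CCc2c(sc(NC(=O)Nc3ccc(Cl)cc3)c2C(N)=O)C1` gives 100 nM

Compound 1 sits within the usual scatter of compound 3, so these two cannot be ranked. Both numbers lie far lower than that of compound 2, a gap well beyond the scatter. Effects therefore appear at much smaller amounts with compound 1 than with compound 2.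

The next compound to be measured is compound 4 `CC(C)(C)C[N+]1(C)CCc2c(sc(NC(=O)Nc3ccc(Cl)cc3)c2C(N)=O)C1`. It differs from compound 1 in one place, a saturated chain carbon bound to an amine nitrogen in a ring, where tert-butyl stands in place of 3-(tert-butoxycarbonyl)propyl: tert-butyl in place of 3-(tert-butoxycarbonyl)propyl on a saturated chain carbon bound to an amine nitrogen in a ring. Cut one bond further out, the same difference reads 4-(tert-butoxycarbonyl)butyl to neopentyl.

For the measured compounds named here, no measured pair isolates this change, so the expectation rests on the values alone. Compound 3 carries other groups on the ring amine nitrogen, yet its 100 nM stays within the scatter of compound 1. On that basis, no step beyond the scatter is expected in this assay, and the estimated step of a 1.1-fold higher number from compound 1 to compound 4 (0.03 log units; within the scatter) is small. Compound 2, at 4700 nM, shows that much higher numbers occur among these compounds, so the expected range reaches further upward. For compound 4 the estimated value is 150 nM, with an expected range of 50 nM to 600 nM.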

Compound 4, half-maximal effective concentration: 290 nM
For compound 4 the middle estimate is 1.9-fold (0.29 log units) below the measured one; the measured number falls inside the stated range.
By their numbers in this assay, from the lowest: compounds 3 and 1 (each within the scatter of the next); then compound 4; then compound 2.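

For the compounds shown here, this is the first pair of compounds that differ in only one place, so the earlier compounds could not show what this position contributes on its own. In this assay, replacing 3-(tert-butoxycarbonyl)propyl, with 10 heavy atoms including 2 oxygens, by tert-butyl, with 4 carbons and no oxygen, gives a 2.1-fold higher number from compound 1 to compound 4 (0.32 log units; beyond the scatter), a modest step that shows this position responds to the change but that the tert-butoxycarbonyl group is not essential for an effect at nanomolar amounts. Nothing available explains why the number rises.

Compound 4 changes the size of the group, its chain and its oxygen content all at once, and the compounds shown do not separate these differences. They also leave open how this assay would read a simple unbranched butyl chain, or a chain of the same length as in compound 1 ending in a carboxylic acid or an amine, which would help show whether the chain or its end group matters more.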